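Bromophenyl swap on the methylpiperidine side of the series

The source may hold more compounds than are shown below. What is called first, only, known or untested is meant among the compounds shown, and "the series" means these compounds.

Two compounds of the shared core have numbers in a functional assay on MKN-45 cells (Homo sapiens) for cytotoxicity, read by MTT assay, with a stated time of 72 h; on this read-out higher numbers stand for weaker inhibition and lower numbers for stronger inhibition. Compound 1 `COc1cc2c(Oc3ccc(NC(=O)c4nn(-c5ccc(Br)cc5)c(=O)c5ccccc45)cc3F)ccnc2cc1OCCCN1CCCCC1` gives 500 nM in this assay. Compound 2 `COc1cc2c(Oc3ccc(NC(=O)c4nn(-c5cccc(F)c5)c(=O)c5ccccc45)cc3F)ccnc2cc1OCCCN1CCC(C)CC1` gives 220 nM, the lowest of the two numbers, with compound 1 standing higher by a gap beyond the scatter. Compound 3 `COc1cc2c(Oc3ccc(NC(=O)c4nn(-c5ccc(Br)cc5)c(=O)c5ccccc45)cc3F)ccnc2cc1OCCCN1CCC(C)CC1` carries 4-bromophenyl in place of 3-fluorophenyl on an aromatic nitrogen. Compounds 1 and 2 differ in two places, so the share of this swap in their gap cannot be separated. A step from compound 2 to compound 3 of a 1.6-fold higher number from compound 2 to compound 3 (0.20 log units; within the scatter) is expected, a modest rise at most. Compound 3 is expected to give 350 nM in this assay, with a range from 150 nM to 900 nM.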

Compound 3, half-maximal inhibitory concentration: 330 nM
Estimate against measurement, compound 3: 1.1-fold (0.03 log units) above, and the stated range covers the measured number.
By their numbers in this assay, from the lowest: compounds 2, 3 and 1 (each within the scatter of the next, the first and the last beyond it).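

In this assay the swap of 3-fluorophenyl for 4-bromophenyl on the aromatic nitrogen is now isolated as a single change (a 1.5-fold higher number from compound 2 to compound 3 (0.18 log units; within the scatter)). Methyl in place of hydrogen on a saturated ring carbon is isolated too (a 1.5-fold lower number from compound 1 to compound 3 (0.18 log units; within the scatter)), so each change alone stays within the scatter, although the two together separate compound 1 from compound 2. No measurement on hand explains either step.

The effect of halogen identity apart from ring position remains open, as 4-fluorophenyl and 3-bromophenyl are not among these compounds. Plain phenyl or pyridyl on that nitrogen, and morpholine in place of the piperidine, also remain open.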